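Swapping cyclopropylmethyl for isopropyl on compound 2

The compounds below may be only part of what the source reports. "The series", "measured", "known", "first", "only" and "open" are said of these compounds alone.

- Compound 1 `CN1CCN(c2ccc(Nc3ncc4nc([S+]([O-])c5ccccc5)n([C@H]5CC[C@H](O)CC5)c4n3)cc2)CC1`: 268 nM
- Compound 2 `CN1CCN(c2ccc(Nc3ncc4nc([S+]([O-])c5ccccc5)n(CC5CC5)c4n3)cc2)CC1`: 838 nM
- Compound 3 `CN1CCN(c2ccc(Nc3ncc4nc(Sc5ccccc5)n(C5CCCC5)c4n3)cc2)CC1`: 51.2 nM

In a functional assay on HCC827 cells (Homo sapiens) for antiproliferative activity, read by MTT assay, with a stated time of 72 h (a lower number here means a stronger inhibitor, a higher number a weaker inhibitor), compound 2 gives the highest number of the three, which makes it the weakest inhibitor in this small set. Compound 4 `CC(C)n1c([S+]([O-])c2ccccc2)nc2cnc(Nc3ccc(N4CCN(C)CC4)cc3)nc21` has not yet been measured. It carries isopropyl in place of cyclopropylmethyl on an aromatic nitrogen.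

Among the compounds with values here, only one measured step involves that nitrogen: a 3.1-fold higher number from compound 1 to compound 2 (0.50 log units; beyond the scatter). That step is modest. Compound 3 is not joined to the others by a change in one place, so it offers no direct guide. Neither group in the new swap has hydrogen-bond donors or acceptors. A step no larger than the one measured is therefore expected, quite possibly none beyond the scatter, with a slight lean toward a lower number.

The expected step is a 1.5-fold lower number from compound 2 to compound 4 (0.18 log units; within the scatter). For compound 4 the estimated value is 550 nM, with an expected range of 200 nM to 1400 nM.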

Compound 4, half-maximal inhibitory concentration: 215 nM
Compound 4: the middle estimate sits 2.6-fold (0.41 log units) above what was measured; the range from low to high includes it.
By their numbers in this assay, from the lowest: compound 3; then compounds 4 and 1 (each within the scatter of the next); then compound 2.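

In this assay, isopropyl in place of cyclopropylmethyl gives a 3.9-fold lower number from compound 2 to compound 4 (0.59 log units; beyond the scatter), so swapping one all-carbon group for another, neither with hydrogen-bond donors or acceptors, is enough to move the number at this aromatic nitrogen. Replacing 4-hydroxycyclohexyl with isopropyl gives a 1.2-fold lower number from compound 1 to compound 4 (0.10 log units; within the scatter), so the hydroxyl and ring of that group are not needed to reach this level of activity. Nothing measured here explains why cyclopropylmethyl stands apart from the other two groups.

On these data alone, it remains open whether an amine or a longer chain on this nitrogen would hold that level. Compound 3, at 51.2 nM, differs from the others in more than one place, so the shares of its cyclopentyl group and its different sulfur link in that value remain unresolved.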